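The source may hold more compounds than are shown below. What is called first, only, known or untested is meant among the compounds shown, and "the series" means these compounds.

Measured and open compounds:
- compound 1 `COc1cc2c(cc1OC)C(c1ccc(Br)cc1)=NNC(=O)C2` – 123 umol/kg
- compound 2 `COc1cc2c(cc1OC)C(c1ccc(C#N)cc1)=NNC(=O)C2` – > 150 umol/kg
- compound 3 `COc1cc2c(cc1OC)C(c1ccc([N+](=O)[O-])cc1)=NNC(=O)C2` – not yet measured

The read-out throughout is a functional assay on the whole organism with Mus musculus as the target, in the maximal electroshock model, with a stated time of 45 min; a lower number here means that less compound is needed, a higher number that more compound is needed for the effect.

Compound 1 gives a true number, 123 umol/kg, in this assay.

Compound 2 gives > 150 umol/kg, which is a limit of the assay and not a number. Compound 2 thus stands at the limit of > 150 umol/kg in this assay, at which 1 of the 2 values shown sits.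

The next change puts nitro in place of cyano on an aromatic carbon, para to a large group, and leads to compound 3 (nitro in place of cyano on an aromatic carbon).

For the measured compounds named here, only one measured step bears on this place: an at least 1.2-fold higher number from compound 1 to compound 2 (0.08 log units; that floor lies within the scatter), with cyano in place of bromo on an aromatic carbon. Going by the values given here, its size is known only as a floor, and no measured step involves nitro. With compound 2 known only by its limit, no direction can be taken from the series, and no step beyond the scatter is expected.

The expected step is an at least 1.0-fold lower number from compound 2 to compound 3 (0.02 log units; that floor lies within the scatter).

For compound 3 the estimated value is 140 umol/kg, with an expected range from 70 umol/kg to 280 umol/kg.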

Compound 3, dose for half-maximal effect: > 150 umol/kg
Compound 3: no number, only a limit; the forecaster's own chance of this, stated with the estimate: 45%; at least 1.0-fold (0.02 log units) between middle value and limit.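

At the aromatic carbon para to a large group, nitro in place of bromo, like cyano before it, ends at a limit of the assay and not at a number in this assay: the limit of > 150 umol/kg in this assay, at which 2 of the 3 values shown sit.

Against the bromo compound, the reading is an at least 1.2-fold higher number from compound 1 to compound 3 (0.08 log units; that floor lies within the scatter), so this second replacement also gives only a floor that stays within the usual scatter. The step between the cyano and nitro compounds cannot be read, since both are known only as limits, and compound 1 remains the only one of the three with a true number.

On these data alone, how far compound 2 and compound 3 lie past their limits stays open, as does whether either truly differs from compound 1 by more than the scatter. Also open, as far as these compounds go, is how an amine or a carboxylic acid on this aromatic carbon would read in this assay, and whether any group there needs less compound for the effect than bromo does.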